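Replacing the oxazole aryl group with trifluoromethyl

A few compounds are considered here, and "the series" means these few. Any claim that something is new, unique, unknown or untested is made for them only; others in the source may bear on it.

Compound 1 `O=C(CCCCCCc1ccccc1)c1nc(-c2ccccn2)co1`: 30 nM in an assay on isolated protein for inhibition of Fatty-acid amide hydrolase 1 (Rattus norvegicus); on this read-out lower numbers stand for stronger inhibition and higher numbers for weaker inhibition
Compound 2 `O=C(CCCCCCc1ccccc1)c1nc(-c2ccncc2)co1`: 140 nM in this assay

Going by the values given here, compound 2 gives the higher of the two numbers measured: the one step seen, a 4.7-fold higher number from compound 1 to compound 2 (0.67 log units; beyond the scatter), separates it from compound 1. Compound 3 `O=C(CCCCCCc1ccccc1)c1nc(C(F)(F)F)co1` carries the change (trifluoromethyl in place of pyridin-4-yl on an aromatic carbon). Among the compounds with values here, no measured step involves a trifluoromethyl group, so the one known step offers no direct guidance; it only shows that the group at this position matters. The estimate for compound 3 is therefore a further weakening, a 2.1-fold higher number from compound 2 to compound 3 (0.33 log units; beyond the scatter), so that compound 3 is expected at 300 nM with a range from 80 nM to 1200 nM.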

Compound 3, half-maximal inhibitory concentration: 400 nM
Beside the measured number, compound 3's estimate is 1.3-fold (0.12 log units) below it; the range from low to high includes it.
By their numbers in this assay, from the lowest: compound 1; then compound 2; then compound 3.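

In this assay, trifluoromethyl in place of the pyridine ring gives a 2.9-fold higher number from compound 2 to compound 3 (0.46 log units; beyond the scatter), and measured against the better pyridine, a 13-fold higher number from compound 1 to compound 3 (1.12 log units; beyond the scatter). Inhibition therefore persists at this position without any ring, although both pyridinyl compounds give lower numbers than the ringless compound 3. Nothing available explains this loss. On these data alone, whether pyridin-3-yl, phenyl or an amine at this position would give a lower number than compound 1 remains open, as does whether a methyl group would behave like trifluoromethyl.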